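This account rests on a few compounds, and the source may have more. Where it says the series, first, only, none or still open, it means among the compounds named here.

In a functional assay on HepG2 cells (Homo sapiens) for antiproliferative activity, read by MTT assay, with a stated time of 24 h (on this read-out higher numbers stand for weaker inhibition and lower numbers for stronger inhibition), compound 1 `COc1ccc(C(=O)/C=C/c2ccc(F)cc2)c2c1C=CC(C)(C)O2` gives > 10000 nM as a limit, not a number. Compound 2 `COc1ccc(C(=O)/C=C/c2ccc(Cl)cc2)c2c1C=CC(C)(C)O2` gives > 10000 nM as a limit too, so it has no number of its own. Within the data shown here, the series so far offers only the limit of > 10000 nM in this assay, at which 2 of the 2 values shown sit, as its evidence.

Compound 3 `COc1ccc(C(=O)/C=C/c2cccc(O)c2)c2c1C=CC(C)(C)O2` carries 3-hydroxyphenyl in place of 4-chlorophenyl on a double-bonded chain carbon bound to a double-bonded chain carbon, with 3-hydroxyphenyl in place of 4-chlorophenyl on a double-bonded chain carbon bound to a double-bonded chain carbon as the count.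

Among the measured compounds shown here, the one measured step is a step that the two limits leave unreadable from compound 1 to compound 2 and gives no size or direction to carry over. No step beyond the scatter can therefore be expected in this assay on measured grounds. The expectation stays near the limit of compound 2 at > 10000 nM for that reason. The expected move is a step that the limit leaves unreadable from compound 2 to compound 3 as an estimate only. Compound 3 is estimated at 12000 nM with an expected range of 3000 nM to 40000 nM in this estimate.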

Compound 3, half-maximal inhibitory concentration: > 10000 nM
Compound 3 was reported as a limit; the forecaster's own chance of this, stated with the estimate: 60%; the middle value lies beyond the limit too.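

Among these compounds, compound 3 gives only a limit in this assay, so no step among compound 1, compound 2 and compound 3 can be read: the limit of > 10000 nM in this assay, at which 3 of the 3 values shown sit.

The compounds shown leave open whether any change at this chain carbon would bring a value in this assay that can be read as a number.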